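Urea series: bicyclic nitrogen placement and TRPV1 inhibition

The source may report more compounds than this note shows. Statements on the series, on what has been measured and on what is new or still open speak of the compounds shown alone.

Two ureas built on the shared core have numbers in an assay on isolated protein for antagonist activity at transient receptor potential cation channel subfamily V member 1 (Homo sapiens), read by FLIPR; on this read-out lower numbers stand for stronger inhibition and higher numbers for weaker inhibition. Compound 1 `CC1CCN(c2nc(C(F)(F)F)ccc2CNC(=O)Nc2ccc3ccncc3c2)CC1` carries isoquinolin-7-yl on the urea nitrogen; in this assay compound 1 gives 8.4 nM. Compound 2 `CC1CCN(c2nc(C(F)(F)F)ccc2CNC(=O)Nc2cccc3cnccc23)CC1` carries isoquinolin-5-yl instead, and in this assay compound 2 gives 0.2 nM. The step of a 42-fold lower number from compound 1 to compound 2 (1.62 log units; beyond the scatter) is the only one measured, and it is large. Compound 2 therefore stands with the lowest number of the two.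

Compound 3 `CC1CCN(c2nc(C(F)(F)F)ccc2CNC(=O)Nc2cccc3ncccc23)CC1` is not yet measured. It differs from compound 2 by quinolin-5-yl in place of isoquinolin-5-yl on an amide-type nitrogen; the two groups have the same atoms, joined differently. For the measured compounds named here, no measured step changes isoquinolinyl into quinolinyl, so the only guide is the step from compound 1 to compound 2, which shows that the bicyclic group in this place can shift the number a great deal. The direction for compound 3 is open; with compound 2 already at the lowest number, the expectation is a moderate rise, a 4.0-fold higher number from compound 2 to compound 3 (0.60 log units; beyond the scatter), estimated with wide bounds. Compound 3 is estimated at 0.8 nM, expected between 0.15 nM and 6 nM.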

Compound 3, inhibition constant: 0.7 nM
The estimate for compound 3 lay 1.1-fold (0.06 log units) above the measured number; measured number inside the range.
By their numbers in this assay, from the lowest: compound 2; then compound 3; then compound 1.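

In this assay, quinolin-5-yl in place of isoquinolin-5-yl on the amide-type nitrogen gives a 3.5-fold higher number from compound 2 to compound 3 (0.54 log units; beyond the scatter) as a modest step beyond the scatter, so rejoining the same atoms while keeping the 5-yl attachment still moves the number. Quinolin-5-yl in place of isoquinolin-7-yl gives a 12-fold lower number from compound 1 to compound 3 (1.08 log units; beyond the scatter) as a large step, so low numbers at this position are not confined to isoquinolin-5-yl, and among these three compounds both 5-yl groups give lower numbers than the 7-yl group, with none going against that order. No measurement on hand accounts for either step.

Quinolin-7-yl would be needed to separate the effect of the attachment point from that of the ring arrangement, since the present set holds a 7-yl group only as isoquinolin-7-yl. As far as these compounds go, how an all-carbon naphthalen-1-yl on the same amide-type nitrogen would compare with quinolin-5-yl and isoquinolin-5-yl also remains open, so the part played by the ring nitrogen itself cannot yet be judged.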